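A few compounds are considered here, and "the series" means these few. Any claim that something is new, unique, unknown or untested is made for them only; others in the source may bear on it.

Of the compounds shown here, three built on a shared core have been measured in an ADME assay on HepG2 cells (Homo sapiens) for cytotoxicity, read by MTT assay, with a stated time of 48 h; a lower number here means that less compound is tolerated, a higher number that more compound is tolerated. Compound 1 `C#CCN(c1nc(-c2cccc(C)c2)no1)C1CCCCC1` gives 44.4 ug/mL in this assay. Compound 2 `C#CCOc1ccc(-c2noc(NC3CCCCC3)n2)cc1` gives 119 ug/mL in this assay. Within the data shown here, compound 3 `C#CCOc1ccc(-c2noc(N(CC#C)C3CCCCC3)n2)cc1` stands at a limit of this assay, > 200 ug/mL, so only a range is known for it; it is the single value at the limit of > 200 ug/mL in this assay, at which 1 of the 3 values shown sits. Among the measured compounds shown here, the one measured step is an at least 1.6-fold higher number from compound 2 to compound 3 (0.22 log units; that floor lies within the scatter), and that change lies elsewhere than the one now considered. Compound 4 `C#CCN(c1nc(-c2ccc(C#C)cc2)no1)C1CCCCC1` differs from compound 3 by ethynyl in place of propargyloxy on an aromatic carbon. For the measured compounds named here, no measured step bears on this exchange, so no step beyond the scatter is expected in this assay, with the reservation that compound 3 is known only as a limit. The estimate for compound 4 is 130 ug/mL, ranging from 50 ug/mL to 250 ug/mL, an expected step of an at least 1.5-fold lower number from compound 3 to compound 4 (0.18 log units; that floor lies within the scatter).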

Compound 4, half-maximal cytotoxic concentration: 28 ug/mL
Compound 4: the middle estimate sits 4.6-fold (0.67 log units) above what was measured, outside the stated range (below it).
By their numbers in this assay, from the lowest: compounds 4 and 1 (each within the scatter of the next); then compound 2. At a limit, above all of these: compound 3.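

The exchange of propargyloxy for ethynyl, on an aromatic carbon para to a large group, gives in this assay an at least 7.1-fold lower number from compound 3 to compound 4 (0.85 log units; beyond the scatter), the first step read at this position. The number therefore responds to the group held there, while the propargyl on the nitrogen stays the same. That step is only a floor, because compound 3 stands at a limit: the limit of > 200 ug/mL in this assay, at which 1 of the 4 values shown sits.

The compounds shown do not separate the loss of the oxygen from the shortening of the group. From the compounds shown here alone, how a methoxy, a hydroxyl or an amine on this carbon would read in this assay remains open.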